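The source may report more compounds than this note shows. Statements on the series, on what has been measured and on what is new or still open speak of the compounds shown alone.

Compound 1 `O=C(/C=C\Nc1ccc(F)cc1)c1nc(-c2ccc(C(F)(F)F)cc2)n2ccccc12` belongs to a set of three compounds on a shared core examined in a functional assay on B16-F10 cells (Mus musculus) for cytotoxicity, read by MTT assay, with a stated time of 48 h; a higher number here means a weaker inhibitor, a lower number a stronger inhibitor. In this assay compound 1 gives > 30000 nM, which is a limit of the assay and not a number. Compound 2 `COc1ccc(-c2nc(C(=O)/C=C\Nc3ccc(F)cc3)c3ccccn23)cc1` carries methoxy in place of trifluoromethyl on an aromatic carbon. In this assay compound 2 gives > 30000 nM, again a limit rather than a number. The step from compound 1 to compound 2 therefore reads a step that the two limits leave unreadable from compound 1 to compound 2. Within the data shown here, compound 3 `COc1ccc(N/C=C\C(=O)c2nc(-c3ccc(F)cc3)n3ccccc23)cc1` differs from compound 1 in more than one place, and in this assay compound 3 gives 2560 nM, the only number among the three. Compound 1 thus stands at the limit of > 30000 nM in this assay, at which 2 of the 3 values shown sit.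

Compound 4 `O=C(/C=C\Nc1ccc2cc[nH]c2c1)c1nc(-c2ccc(C(F)(F)F)cc2)n2ccccc12` has not yet been measured. It differs from compound 1 by 1H-indol-6-yl in place of 4-fluorophenyl on an amine nitrogen. Among the measured compounds shown here, no measured step touches the group on the amine nitrogen; the single measured step, a step that the two limits leave unreadable from compound 1 to compound 2, concerns an aromatic carbon elsewhere and is itself unreadable. For the measured compounds named here, compound 3 shows that a number can be reached on this core, but it offers no single step to compound 1. The direction of the change in this assay is therefore open, and a limit remains a real possibility. The estimate for compound 4 is 20000 nM, with a range from 3000 nM to 60000 nM. The step this estimate implies is expected to be an at least 1.5-fold lower number from compound 1 to compound 4 (0.17 log units; that floor lies within the scatter).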

Compound 4, half-maximal inhibitory concentration: > 30000 nM
Compound 4 gave a limit, no number; the forecaster's own chance of this, stated with the estimate: 50%; at least 1.5-fold (0.17 log units) between middle value and limit.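

In this assay compound 4 gives > 30000 nM, which is a limit of the assay and not a number. Compound 1 also stands at a limit, so the step between compound 1 and compound 4 cannot be read. The compounds shown leave open whether 1H-indol-6-yl in place of 4-fluorophenyl on an amine nitrogen changes the read-out at all, and the set now reads: the limit of > 30000 nM in this assay, at which 3 of the 4 values shown sit.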